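This account rests on a few compounds, and the source may have more. Where it says the series, first, only, none or still open, it means among the compounds named here.

Compound 1 `CCCCCCCCCCn1cc(COC[C@@H]2OC[C@H](N)[C@@H]2O)nn1`: 9640 nM
Compound 2 `CCCCCCCn1cc(COC[C@@H]2OC[C@H](N)[C@H]2O)nn1`: > 128000 nM, a limit
Compound 3 `CCCCCCCCCn1cc(COC[C@@H]2OC[C@H](N)[C@H]2O)nn1`: > 128000 nM, a limit

In a functional assay on MCF7 cells (Homo sapiens) for antiproliferative activity, read by MTT assay, with a stated time of 48 h (on this read-out lower numbers stand for stronger inhibition and higher numbers for weaker inhibition), compound 3 gives no number, only a limit: > 128000 nM. Compound 3 thus sits at the limit of > 128000 nM in this assay, at which 2 of the 3 values shown sit. Compound 4 `CCCCCCCCCCn1cc(COC[C@@H]2OC[C@H](N)[C@H]2O)nn1` differs from it by methyl in place of hydrogen on a saturated chain carbon, nine bonds along the chain from an aromatic nitrogen.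

Among the measured compounds shown here, the one measured step bearing on this is a step that the two limits leave unreadable from compound 2 to compound 3, so it offers no size to carry over. Compound 1 alone has a number, 9640 nM. A shift toward stronger inhibition is therefore only a cautious expectation, and a further limit remains quite possible. The expected change is an at least 1.8-fold lower number from compound 3 to compound 4 (0.26 log units; that floor lies within the scatter). For compound 4 the estimate is 70000 nM, with an expected range from 15000 nM to 128000 nM.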

Compound 4, half-maximal inhibitory concentration: 45000 nM
Beside the measured number, compound 4's estimate is 1.6-fold (0.19 log units) above it, and the stated range covers the measured number.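

In this assay, among the compounds shown here, methyl in place of hydrogen on a saturated chain carbon, nine bonds along the chain from an aromatic nitrogen, brings the first readable number for this configuration, with an at least 2.8-fold lower number from compound 3 to compound 4 (0.45 log units; beyond the scatter), while the larger change gives an at least 2.8-fold lower number from compound 2 to compound 4 (0.45 log units; beyond the scatter). Both steps start from a limit of the assay: the limit of > 128000 nM in this assay, at which 2 of the 4 values shown sit. Configuration also counts, with a 4.7-fold higher number from compound 1 to compound 4 (0.67 log units; beyond the scatter), and this gap traces to the drawn stereocentre alone: the fact that compounds 1 and 4 differ only in the configuration as drawn. On these data alone, whether a longer chain such as dodecyl would lower the number further, in either configuration, stays open.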